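Furan-2-yl for Pyrazin-2-yl at the Amine-Bound Methylene

The source may report more compounds than this note shows. Statements on the series, on what has been measured and on what is new or still open speak of the compounds shown alone.

Compound 1, `Nc1nc(NCc2cccs2)nc2sc(-c3ccco3)nc12`, gives 6.43 nM in an assay on CHO cells for displacement of a labelled ligand from adenosine receptor A3 (Homo sapiens), read by scintillation counting, with a stated time of 120 min; on this read-out lower numbers stand for stronger inhibition and higher numbers for weaker inhibition.
Compound 2, `Nc1nc(NCc2cccs2)nc2sc(-c3cccs3)nc12`, gives 38 nM in this assay.
Compound 3, `Nc1nc(NCc2cnccn2)nc2sc(-c3ccco3)nc12`, gives 157 nM in this assay.

Compound 3 stands highest of the three. Its nearest neighbour is compound 2, and the pair shows a gap beyond the scatter; the furthest is compound 1, with a 24-fold higher number from compound 1 to compound 3 (1.39 log units; beyond the scatter). Compound 4, `Nc1nc(NCc2ccco2)nc2sc(-c3ccco3)nc12`, is not yet measured. It differs from compound 3 by furan-2-yl in place of pyrazin-2-yl on a saturated chain carbon bound to a nitrogen on an aromatic ring.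

Among the compounds with values here, the step that bears on this change is the one between compound 1 and compound 3, the large 24-fold higher number from compound 1 to compound 3 (1.39 log units; beyond the scatter), which concerns the same place on the chain carbon bound to the ring nitrogen. The step of a 5.9-fold higher number from compound 1 to compound 2 (0.77 log units; beyond the scatter) touches the other position, where thiophen-2-yl replaced furan-2-yl, and was modest. Since furan-2-yl now enters where pyrazin-2-yl leaves, a large drop in number is expected, close to reversing the earlier step.

Compound 4 is therefore estimated at 12 nM, in the range 4 nM to 40 nM, which is expected to mean a 13-fold lower number from compound 3 to compound 4 (1.12 log units; beyond the scatter).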

Compound 4, inhibition constant: 4.72 nM
For compound 4 the middle estimate is 2.5-fold (0.41 log units) above the measured one; low and high end bracket the measured number.
By their numbers in this assay, from the lowest: compounds 4 and 1 (each within the scatter of the next); then compound 2; then compound 3.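

At this place, on a saturated chain carbon bound to a nitrogen on an aromatic ring, furan-2-yl in place of pyrazin-2-yl gives a 33-fold lower number from compound 3 to compound 4 (1.52 log units; beyond the scatter) in this assay and so shows that the high number of compound 3 is not tied to thiophen-2-yl alone. Furan-2-yl and thiophen-2-yl cannot be told apart here, with a 1.4-fold lower number from compound 1 to compound 4 (0.13 log units; within the scatter) at this place. The same two rings do differ at the other place, on an aromatic carbon, where thiophen-2-yl in place of furan-2-yl gives a 5.9-fold higher number from compound 1 to compound 2 (0.77 log units; beyond the scatter) and lies beyond the scatter.

The compounds shown do not separate ring size from the hetero atoms in pyrazin-2-yl, and a phenyl ring at this place would bear on that. No evidence accompanies these numbers that could account for them.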